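Isobutyl on the aromatic nitrogen: notes on compound 4

The source may hold more compounds than are shown below. What is called first, only, known or untested is meant among the compounds shown, and "the series" means these compounds.

Values in a functional assay on HCT-15 cells (Homo sapiens) for antiproliferative activity, read by MTT assay, with a stated time of 72 h (on this read-out lower numbers stand for stronger inhibition and higher numbers for weaker inhibition), follow, each one a limit and not a number
- compound 1 `CCn1ccnc1-c1cc(OC)c(OC)c(OC)c1` gives > 100000 nM as a limit
- compound 2 `CCCn1ccnc1-c1cc(OC)c(OC)c(OC)c1` gives > 100000 nM as a limit
- compound 3 `COc1cc(-c2nccn2C(C)C)cc(OC)c1OC` gives > 100000 nM as a limit

Compound 3 stands at the limit of > 100000 nM in this assay, at which 3 of the 3 values shown sit, and so offers no number to start from. Compound 4 `COc1cc(-c2nccn2CC(C)C)cc(OC)c1OC` is not yet measured. The change is isobutyl in place of isopropyl on an aromatic nitrogen with the shared core untouched. Three measured changes to the chain on that nitrogen bear on it, namely a step that the two limits leave unreadable from compound 1 to compound 2 and a step that the two limits leave unreadable from compound 1 to compound 3 and a step that the two limits leave unreadable from compound 2 to compound 3 and none of them gives a size. In this assay no step beyond the scatter is therefore expected, and no direction is expected either. The estimated outcome is a number no higher from compound 3 to compound 4 (the limit leaves the size open) and a report as a limit is the likely form. For compound 4 the estimated value is 100000 nM with an expected range from 40000 nM to 200000 nM in this estimate.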

Compound 4, half-maximal inhibitory concentration: > 100000 nM
Compound 4 gave a limit, no number; the forecaster's own chance of this, stated with the estimate: 85%; the middle value sits exactly at the limit.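

No step can be read between compound 4 and compounds 1, 2 or 3 in this assay, because all four stand at one limit and give no number: the limit of > 100000 nM in this assay, at which 4 of the 4 values shown sit.

The compounds shown leave open whether any chain on the aromatic nitrogen changes the read-out, and in which direction.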